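Acyl Group Change and Cell Cytotoxicity in One Series

The source may hold more compounds than are shown below. What is called first, only, known or untested is meant among the compounds shown, and "the series" means these compounds.

Compound 1, `COC[C@H]1CN(c2ccc(-n3cc(-c4ccccn4)cn3)c(F)c2)C(=O)O1`, gives in an ADME assay on HEK293-A cells (Homo sapiens) for cytotoxicity, read by MTT assay, with a stated time of 48 h (a lower number here means a stronger inhibitor, a higher number a weaker inhibitor), only a limit, > 400 ug/mL.
Compound 2, `CS(=O)(=O)NC[C@H]1CN(c2ccc(-n3cc(-c4ccccn4)cn3)c(F)c2)C(=O)O1`, gives in this assay 314 ug/mL.
Compound 3, `CCNC(=O)NC[C@H]1CN(c2ccc(-n3cc(-c4ccccn4)cn3)c(F)c2)C(=O)O1`, gives in this assay 29 ug/mL.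

Compound 3 holds the lowest of the two numbers; the step of an 11-fold lower number from compound 2 to compound 3 (1.03 log units; beyond the scatter) lies beyond the scatter, and an at least 13-fold lower number from compound 1 to compound 3 (1.13 log units; beyond the scatter) is measured against the limit (the limit of > 400 ug/mL in this assay, at which 1 of the 3 values shown sits). The step of an at least 1.2-fold lower number from compound 1 to compound 2 (0.10 log units; that floor lies within the scatter) stays within the scatter. Compound 4, `O=C1O[C@@H](CNC(=O)C(F)(F)F)CN1c1ccc(-n2cc(-c3ccccn3)cn2)c(F)c1`, differs from compound 3 by trifluoromethyl in place of ethylamino on a carbonyl carbon. No measured step alters the group on this carbonyl carbon; the steps shown only tell that the (ethylcarbamoyl)amino group sits far below the methoxy and methanesulfonamido groups. The number for compound 4 is therefore expected to rise part of the way back, a 3.4-fold higher number from compound 3 to compound 4 (0.54 log units; beyond the scatter). The estimate for compound 4 is 100 ug/mL, ranging from 25 ug/mL to 400 ug/mL.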

Compound 4, half-maximal inhibitory concentration: > 400 ug/mL
Compound 4: a limit, no number; the forecaster's own chance of this, stated with the estimate: 20%; middle value at least 4.0-fold (0.60 log units) away from the limit.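

Trifluoromethyl in place of ethylamino on the carbonyl carbon gives an at least 13-fold higher number from compound 3 to compound 4 (1.13 log units; beyond the scatter) in this assay, so a carbonyl on this amine nitrogen does not by itself bring the low number, which among these compounds only compound 3 shows. Against the methylsulfonyl group, the change to (trifluoromethyl)carbonyl gives an at least 1.2-fold higher number from compound 2 to compound 4 (0.10 log units; that floor lies within the scatter), whose floor stays within the scatter. Compound 4 gives only a limit, and the step from compound 1 to compound 4 cannot be read: the limit of > 400 ug/mL in this assay, at which 2 of the 4 values shown sit.

On these data alone, whether the low number follows the nitrogen of the ethylamino group or its ethyl chain remains open. A methyl group, a methylamino group or a longer alkylamino chain on this carbonyl carbon would bear on that question.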